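The source may hold more compounds than are shown below. What is called first, only, known or untested is meant among the compounds shown, and "the series" means these compounds.

Compound 1 `CN(C)Cc1cc(=O)oc2cc(OCc3ccc(CO)cc3)ccc12` and compound 2 `CN(C)Cc1cc(=O)oc2cc(OCc3cccc(CO)c3)ccc12` share one core and differ in a single place: 3-(hydroxymethyl)phenyl in place of 4-(hydroxymethyl)phenyl on a saturated chain carbon bound to an oxygen on an aromatic ring. In an assay for inhibition of Amine oxidase [flavin-containing] B (Homo sapiens), read by fluorescence, using microsomes, with a stated time of 30 min (a lower number here means a stronger inhibitor, a higher number a weaker inhibitor), compound 1 gives 630 nM, and in the same assay compound 2 gives 1100 nM; the change makes a 1.7-fold higher number from compound 1 to compound 2 (0.24 log units; within the scatter). Compound 3 `Cc1c(C)c2ccc(OCC3CCCN(Cc4ccc(CO)cc4)C3)cc2oc1=O` is built on a different core, and how the core of compound 3 differs from the core of compound 1 is not broken down here. In this assay, among the measured compounds shown here, compound 3 gives 76 nM, the lowest of the three numbers so far, with both of the others beyond the scatter above it.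

Compound 4 `Cc1c(C)c2ccc(OCC3CCCN(Cc4cccc(CO)c4)C3)cc2oc1=O` has not yet been measured. It differs from compound 3 by 3-(hydroxymethyl)phenyl in place of 4-(hydroxymethyl)phenyl on a saturated chain carbon bound to an amine nitrogen in a ring. For the measured compounds named here, this is the same kind of change as the one from compound 1 to compound 2, though not the same: there the place is on a saturated chain carbon bound to an oxygen on an aromatic ring, here it is on a saturated chain carbon bound to an amine nitrogen in a ring. Going by the values given here, the only earlier example of this change made a 1.7-fold higher number from compound 1 to compound 2 (0.24 log units; within the scatter). On that single step, the move from compound 3 to compound 4 in this assay is expected to be of similar size, a 1.7-fold higher number from compound 3 to compound 4 (0.23 log units; within the scatter). Compound 4 is therefore estimated to give 130 nM in this assay, with a likely range from 50 nM to 350 nM.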

Compound 4, half-maximal inhibitory concentration: 110 nM
Estimate against measurement, compound 4: 1.2-fold (0.07 log units) above; the range from low to high includes it.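

Swapping 4-(hydroxymethyl)phenyl for 3-(hydroxymethyl)phenyl on the core of compound 3 gives, in this assay, a 1.4-fold higher number from compound 3 to compound 4 (0.16 log units; within the scatter). Set beside the earlier step, the same swap reads alike on the two cores: the same change on two cores in this assay, a 1.7-fold higher number (0.24 log units; within the scatter) from compound 1 to compound 2 and a 1.4-fold higher number (0.16 log units; within the scatter) from compound 3 to compound 4, 1.2-fold (0.08 log units) apart, within the scatter of two such steps. So, on these two cores, the swap leaves the number inside the usual spread of repeat measurements, and the result on one core would have been a fair guide to the result on the other; it does not show a general rule for the series, since it rests on only two pairs of compounds, and with both steps within the scatter it cannot show that the swap has any real effect at all.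

The compounds shown carry only hydroxymethyl on this phenyl ring, so it remains open whether another group there, such as a carboxylic acid, an amine or a longer chain ending in a hydroxyl, would give a step beyond the scatter. As far as these compounds go, it also remains open whether the swap between these two hydroxymethyl isomers would read the same on any core other than these two.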